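The compounds below may be only part of what the source reports. "The series", "measured", "known", "first", "only" and "open" are said of these compounds alone.

Measured compounds:
compound 1, `Cn1cc(-c2cc(C(O)(C(F)(F)F)C(F)(F)F)cnc2N2CCN(S(=O)(=O)c3ccc(N)nc3)CC2)cn1`, 44 mL.min-1.g-1
compound 2, `CS(=O)(=O)c1ccc(-c2cc(C(O)(C(F)(F)F)C(F)(F)F)cnc2N2CCN(S(=O)(=O)c3ccc(N)nc3)CC2)cc1`, 103 mL.min-1.g-1
compound 3, `Nc1ccc(S(=O)(=O)N2CCN(c3ncc(C(O)(C(F)(F)F)C(F)(F)F)cc3-c3ccncc3)CC2)cn1`, 31 mL.min-1.g-1

All three share one core and differ only in the aromatic group attached to it. In an ADME assay (liver) for metabolic stability, with Liver microsome (Rattus norvegicus) as the target, using microsomes and NADPH, with a stated time of 30 min, tested at 1 uM (a lower number here means slower removal, a higher number faster removal of the compound), compound 3 sits at the low end of the three numbers. Its gap to compound 1, a 1.4-fold lower number from compound 1 to compound 3 (0.15 log units; within the scatter), lies within the scatter, whereas a 3.3-fold lower number from compound 2 to compound 3 (0.52 log units; beyond the scatter) lies beyond it; a 2.3-fold higher number from compound 1 to compound 2 (0.37 log units; beyond the scatter) is likewise a modest step beyond the scatter.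

Compound 4, `Nc1ccc(S(=O)(=O)N2CCN(c3ncc(C(O)(C(F)(F)F)C(F)(F)F)cc3-c3cc4ccccc4[nH]3)CC2)cn1`, has not yet been measured in this assay. It differs from compound 3 in one place: 1H-indol-2-yl in place of pyridin-4-yl on an aromatic carbon. The three measured steps all swap this same aromatic group, and none of them exceeded a modest size. None involves an entering group with a six-membered aromatic ring of carbon only and a hydrogen-bond donor, so the direction is uncertain. Because the step of a 3.3-fold lower number from compound 2 to compound 3 (0.52 log units; beyond the scatter) shows that a change at this position can move the number modestly, a modest step upward is expected, a 2.3-fold higher number from compound 3 to compound 4 (0.35 log units; beyond the scatter), as the estimate. Compound 4 is therefore expected to give about 70 mL.min-1.g-1, within a range from 30 mL.min-1.g-1 to 160 mL.min-1.g-1.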

Compound 4, intrinsic clearance in microsomes: 146 mL.min-1.g-1
Estimate against measurement, compound 4: 2.1-fold (0.32 log units) below; the range from low to high includes it.
By their numbers in this assay, from the lowest: compounds 3 and 1 (each within the scatter of the next); then compounds 2 and 4 (each within the scatter of the next).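

In this assay, 1H-indol-2-yl in place of pyridin-4-yl gives a 4.7-fold higher number from compound 3 to compound 4 (0.67 log units; beyond the scatter), which widens the span seen at this position, although the step is still modest. The high end of the numbers is also not tied to a single kind of group: 1H-indol-2-yl and 4-(methylsulfonyl)phenyl cannot be told apart, with a 1.4-fold higher number from compound 2 to compound 4 (0.15 log units; within the scatter), while 1H-indol-2-yl separates from 1-methyl-1H-pyrazol-4-yl, with a 3.3-fold higher number from compound 1 to compound 4 (0.52 log units; beyond the scatter). No measurement is available that accounts for these differences in removal.

The compounds shown do not separate the added six-membered aromatic ring of carbon only in 1H-indol-2-yl from its hydrogen-bond donor, as the two enter together in compound 4. A 1-methyl-1H-indol-2-yl group, which keeps both rings but carries a methyl on the ring nitrogen, or a plain phenyl would bear on that question, and a carboxylic acid on the ring at this position would show whether the number can be brought below that of compound 3.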